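Compound 3 to compound 4: methoxy in place of amino

The compounds below may be only part of what the source reports. "The series", "measured", "known", "first", "only" and "open" are said of these compounds alone.

In a functional assay on MCF7 cells (Homo sapiens) for cytotoxicity, read by MTT assay, with a stated time of 96 h (on this read-out lower numbers stand for stronger inhibition and higher numbers for weaker inhibition), compound 3 `COc1cc(C(=O)c2cn(-c3ccc(N)cc3)cc2-c2ccccc2)cc(OC)c1OC` is lowest of the three numbers at 35 nM against compound 1 `COc1ccccc1-n1cc(C(=O)c2cc(OC)c(OC)c(OC)c2)c(-c2ccccc2)c1` at 150 nM and compound 2 `COc1cc(C(=O)c2cn(-c3cccc([N+](=O)[O-])c3)cc2-c2ccccc2)cc(OC)c1OC` at 550 nM so far. Compound 4 `COc1ccc(-n2cc(C(=O)c3cc(OC)c(OC)c(OC)c3)c(-c3ccccc3)c2)cc1` carries methoxy in place of amino on an aromatic carbon, para to a large group methoxy in place of amino on an aromatic carbon and so has 4-methoxyphenyl instead of 4-aminophenyl. The nearest evidence is the modest 4.3-fold lower number from compound 1 to compound 3 (0.63 log units; beyond the scatter) with 4-aminophenyl in place of 2-methoxyphenyl. Among the compounds with values here, the large 16-fold lower number from compound 2 to compound 3 (1.20 log units; beyond the scatter) and the modest 3.7-fold higher number from compound 1 to compound 2 (0.56 log units; beyond the scatter) show the reach of this substituent, but no measured compound holds 4-methoxyphenyl. A modest rise is expected in this assay with an estimated 2.6-fold higher number from compound 3 to compound 4 (0.41 log units; beyond the scatter) as the step. Compound 4 is estimated at 90 nM with an expected range of 25 nM to 320 nM for now.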

Compound 4, half-maximal inhibitory concentration: 120 nM
Beside the measured number, compound 4's estimate is 1.3-fold (0.12 log units) below it, within the range that was stated.
By their numbers in this assay, from the lowest: compound 3; then compounds 4 and 1 (each within the scatter of the next); then compound 2.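

In this assay, methoxy in place of amino on an aromatic carbon, para to a large group, gives a 3.4-fold higher number from compound 3 to compound 4 (0.54 log units; beyond the scatter) and so leaves the 4-aminophenyl of compound 3 ahead of the 4-methoxyphenyl. On the aromatic nitrogen, 4-methoxyphenyl in place of 2-methoxyphenyl gives a 1.3-fold lower number from compound 1 to compound 4 (0.10 log units; within the scatter) and does not separate the two methoxyphenyl groups, whereas 4-methoxyphenyl in place of 3-nitrophenyl gives a 4.6-fold lower number from compound 2 to compound 4 (0.66 log units; beyond the scatter) as a clear gain. No evidence on hand accounts for these steps.

Still open, on these data alone, is how a hydroxy or dimethylamino group would compare with amino at this place, and whether an acetamide would retain the low number of compound 3.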